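The compounds below may be only part of what the source reports. "The series", "measured", "known", "first", "only" and "open" are said of these compounds alone.

Working notes on the series. Compound 1 (`O=C1CCC[C@H]([C@@H]2C[C@H]2c2ccccc2)O1`) gives > 100000 nM in a functional assay on HBL-100 cells (Homo sapiens) for antiproliferative activity, read by luminescence and CellTiter-Glo, with a stated time of 48 h (on this read-out lower numbers stand for stronger inhibition and higher numbers for weaker inhibition), as a limit, not a number. Compound 2 (`COc1ccc(/C=C/[C@H]2CC=CC(=O)O2)cc1`) gives > 100000 nM in this assay, again only a limit, so it has no number of its own. Among the compounds with values here, the two compounds share one reading (the limit of > 100000 nM in this assay, at which 2 of the 2 values shown sit), and no step between measured compounds is available to size a change.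

Compound 3 (`O=C1C=CC[C@H](/C=C/c2ccc([N+](=O)[O-])cc2)O1`) is next. It carries nitro in place of methoxy on an aromatic carbon, para to a group of 9 heavy atoms (nitro in place of methoxy on an aromatic carbon), and the rest of the structure stays as in compound 2.

Within the data shown here, with no measured step to lean on, only a small step is expected in this assay, towards stronger inhibition if there is any, and it may not exceed the scatter. The estimated change is an at least 1.6-fold lower number from compound 2 to compound 3 (0.22 log units; that floor lies within the scatter) and it carries wide uncertainty. The expectation starts from compound 2 with > 100000 nM as its limit, and a limit is a real possibility again. Compound 3 is estimated at 60000 nM with a range from 15000 nM to 200000 nM in this reading.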

Compound 3, half-maximal inhibitory concentration: 6700 nM
The estimate for compound 3 lay 9.0-fold (0.95 log units) above the measured number; measured number outside the range, below it.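

At the aromatic carbon para to a group of 9 heavy atoms, nitro in place of methoxy gives, in this assay, an at least 14-fold lower number from compound 2 to compound 3 (1.17 log units; beyond the scatter) and so shows that a change at this position can move the read-out well beyond the usual scatter. Compound 3 is the only compound shown with a number of its own rather than a limit, so the core shared by compound 2 and compound 3 can carry measurable antiproliferative activity on these cells once it bears nitro at this carbon. The size of the step is a floor and not an exact figure, because compound 2 stands at a limit: the limit of > 100000 nM in this assay, at which 2 of the 3 values shown sit.

A single replacement at one position does not separate what nitro contributes from what the departure of methoxy contributes, and compound 1 differs from compound 3 in more than one place, so it offers no comparison. Going by these compounds, whether the read-out responds in the same way to other groups on this aromatic carbon, such as an amine, a nitrile or a carboxylic acid, stays open.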